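Three Coumarin Lipoamide Conjugates and One Dichlorophenyl Estimate

The compounds below may be only part of what the source reports. "The series", "measured", "known", "first", "only" and "open" are said of these compounds alone.

Of the compounds shown here, three built around a shared core have been measured in a functional assay on PC-12 cells (Rattus norvegicus) for cytotoxicity, read by MTT assay, with stated times of 3 h and 2 h, tested at 20 uM; on this read-out lower numbers stand for a weaker effect and higher numbers for a stronger effect at the one concentration tested. Compound 1 `O=C(CCCCC1CCSS1)NCc1cn(CCCOc2ccc3cc(-c4ccc(Br)cc4)c(=O)oc3c2)nn1` gives 69.1%, and compound 2 `Cc1cc(=O)oc2cc(OCCCCCn3cc(CNC(=O)CCCCC4CCSS4)nn3)ccc12` gives 70.3%. Compound 3 `O=C(CCCCC1CCSS1)NCc1cn(CCCCCOc2ccc3cc(-c4ccccc4)c(=O)oc3c2)nn1` gives 20.7%, the lowest of the three numbers; its distance to compound 1 and to compound 2 is in both cases beyond the usual scatter. Going by the values given here, compound 1 and compound 2 differ from compound 3 in more than one place at once, so no single structural step between measured compounds can be isolated.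

Compound 4 `O=C(CCCCC1CCSS1)NCc1cn(CCCCCOc2ccc3cc(-c4ccc(Cl)c(Cl)c4)c(=O)oc3c2)nn1` differs from compound 3 in one place only: 3,4-dichlorophenyl in place of phenyl on an aromatic carbon. Among the compounds with values here, since no measured pair shows what this kind of change does here, the direction can only be guessed. The two compounds that score higher than compound 3 both carry groups other than a plain phenyl at that position, which hints at an upward move, though with wide uncertainty. For compound 4 the expected step in this assay is a number 27.3 percentage points higher from compound 3 to compound 4 (beyond the scatter). Compound 4 is therefore estimated to give 48%, within a range from 18% to 78%.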

Compound 4, a percentage reported as activity, at one concentration (the size of the read-out at that concentration, not a potency): 65.5%
Compound 4: the middle estimate sits 17.5 percentage points below what was measured; the range from low to high includes it.
By their numbers in this assay, from the lowest: compound 3; then compounds 4, 1 and 2 (each within the scatter of the next).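

In this assay, 3,4-dichlorophenyl in place of phenyl on this aromatic carbon gives a number 44.8 percentage points higher from compound 3 to compound 4 (beyond the scatter). Going by these compounds alone, this is the first single-place comparison, and it shows that the group at this position can by itself move the read-out well beyond the scatter, towards a stronger effect at the one concentration tested. The aromatic ring stays in the exchange, two chlorine atoms are added, neither group carries a hydrogen-bond donor, a hydrogen-bond acceptor or a net charge, and nothing available explains the size of the step.

Going by these compounds, it remains open whether a single chlorine, or an amine or a carboxylic acid on the same ring, would move the number in the same way. On these data alone, it is also open whether 3,4-dichlorophenyl would give a similar step on the shorter chain of compound 1.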